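A Single Stereocentre Inverted in a Weakly Cytotoxic Compound

The source may report more compounds than this note shows. Statements on the series, on what has been measured and on what is new or still open speak of the compounds shown alone.

Compound 1 `CC(C)=C1CC[C@]2(C)CC[C@]3(O[C@H](C[C@H]3C)C[C@]3(C)O[C@H]3C1=O)O2` was examined in a functional assay on PC-3 cells (Homo sapiens) for cytotoxicity, read by MTT assay, with a stated time of 24 h; on this read-out lower numbers stand for stronger inhibition and higher numbers for weaker inhibition. In this assay, compound 1 gave only a limit, > 50000 nM. Compound 3 `CC(=O)O[C@]1(C)CCC(=C(C)C)C(=O)[C@@H]2O[C@@]2(C)CC/C=C(\C)[C@H](O)CC1` likewise gave only a limit, > 50000 nM. Compound 1 therefore stands at the limit of > 50000 nM in this assay, at which 2 of the 3 values shown sit. For the measured compounds named here, compound 2 `CC(=O)O[C@@]1(C)CCC(=O)[C@@H](C)CCC[C@]2(C)O[C@H]2C(=O)C(=C(C)C)CC1` is the one compound of these three with an actual number, 24300 nM.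

Compound 4 `CC(C)=C1CC[C@]2(C)CC[C@]3(O[C@H](C[C@@H]3C)C[C@]3(C)O[C@H]3C1=O)O2` has not yet been measured. Its relation to compound 1 is the two compounds have the same atoms and bonds and differ only in configuration as drawn: 1 of 6 stereo elements differ; a stereocentre at a saturated ring carbon is drawn R in compound 1 and S in compound 4: a stereocentre at a saturated ring carbon is drawn R in compound 1 and S in compound 4. Going by the values given here, no measured pair shows what such a change does in this assay, so no shift beyond the scatter is expected in either direction. This expectation starts from compound 1, whose result of > 50000 nM is a limit. The expected change is small, an at least 1.1-fold lower number from compound 1 to compound 4 (0.04 log units; that floor lies within the scatter). The estimate for compound 4 is 45000 nM, with an expected range from 20000 nM to 100000 nM.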

Compound 4, half-maximal inhibitory concentration: > 50000 nM
Compound 4 was reported as a limit (the forecaster's own chance of this, stated with the estimate: 65%); middle value at least 1.1-fold (0.04 log units) from the limit.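

For the compounds shown here, compound 1 and compound 4 both stand only as limits in this assay, so no step between them can be read. The compounds shown leave open whether the configuration at this saturated ring carbon affects the result at all, as neither compound has an actual number.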